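Oxytocin receptor series: exchange of the branched alkyl side chain

The source may report more compounds than this note shows. Statements on the series, on what has been measured and on what is new or still open speak of the compounds shown alone.

Measured so far in an assay on isolated protein for displacement of a labelled ligand from Oxytocin receptor (Homo sapiens); a lower number here means a stronger inhibitor, a higher number a weaker inhibitor:
- compound 1 `CCC(CC)[C@@H]1C(=O)N[C@H](C2Cc3ccccc3C2)C(=O)N1[C@@H](C(=O)N1CCOCC1)c1ccc(C)nc1` gives 0.0251 nM
- compound 2 `Cc1ccc([C@H](C(=O)N(C)C)N2C(=O)[C@@H](C3Cc4ccccc4C3)NC(=O)[C@H]2CC(C)C)cn1` gives 1.59 nM
- compound 3 `CC[C@H](C)[C@@H]1C(=O)N[C@H](C2Cc3ccccc3C2)C(=O)N1[C@@H](C(=O)N1CCOCC1)c1cc(C)cnc1C` gives 0.794 nM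

Compound 1 stands lowest of the three numbers in this assay; compound 3 is nearest, compound 2 furthest, and both gaps lie beyond the scatter. Compound 4 `Cc1ccc([C@H](C(=O)N2CCOCC2)N2C(=O)[C@@H](C3Cc4ccccc4C3)NC(=O)[C@H]2CC2CC2)cn1` is not yet measured. It differs from compound 1 in one place: cyclopropylmethyl in place of pentan-3-yl on a saturated ring carbon. Compound 2 and compound 3, which carry other side chains at that ring carbon together with other changes, sit well above compound 1, so a loss is expected from compound 1 to compound 4, of moderate size, estimated as a 6.0-fold higher number from compound 1 to compound 4 (0.78 log units; beyond the scatter). Compound 4 is expected to give about 0.15 nM, within 0.03 nM to 0.8 nM.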

Compound 4, inhibition constant: 5.01 nM
The estimate for compound 4 lay 33-fold (1.52 log units) below the measured number; the measured number lies above the stated range.
By their numbers in this assay, from the lowest: compound 1; then compounds 3 and 2 (each within the scatter of the next); then compound 4.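

In this assay, within the data shown here, cyclopropylmethyl in place of pentan-3-yl on this saturated ring carbon gives a 200-fold higher number from compound 1 to compound 4 (2.30 log units; beyond the scatter), the first reading of this position with nothing else in the structure changed. Among these compounds, this side chain alone therefore carries a large loss, which the earlier compounds, differing in several places at once, could not isolate. Nothing at hand accounts for the size of this step.

As far as these compounds go, whether cyclopentyl or a straight pentyl chain on the core of compound 1 would keep the low number stays open. So does whether a step of this size would recur with a different amide or pyridine substitution elsewhere on the core.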